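This account rests on a few compounds, and the source may have more. Where it says the series, first, only, none or still open, it means among the compounds named here.

This account follows a small set of diaryl ureas examined in a functional assay on HepG2 cells (Homo sapiens) for cytotoxicity, read by MTT assay, with a stated time of 72 h; on this read-out higher numbers stand for weaker inhibition and lower numbers for stronger inhibition. Compound 1 `O=C(Nc1ccc(-n2ncc3c(Br)cccc32)cc1)Nc1ccc(Cl)c(C(F)(F)F)c1` gives 2000 nM in this assay. Compound 2 `O=C(Nc1ccc(-n2ncc3c(Cl)cccc32)cc1)Nc1ccc(C(F)(F)F)cc1` gives 6700 nM in this assay. Compound 1 therefore stands with the lowest of the two numbers, and its gap to compound 2 lies beyond the usual scatter of repeated measurements of this kind.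

Compound 3 `O=C(Nc1ccc(-n2ncc3cccnc32)cc1)Nc1ccc(Cl)c(C(F)(F)F)c1` has not yet been measured. It differs from compound 1 in one place: a group of 9 heavy atoms (6 carbon, 3 nitrogen; one five-membered aromatic ring with 2 hetero atoms, one six-membered aromatic ring with 1 hetero atom) in place of a group of 10 heavy atoms (7 carbon, 2 nitrogen, 1 bromine; one five-membered aromatic ring with 2 hetero atoms, one six-membered aromatic ring of carbon only), on an aromatic carbon. In words, the 4-bromo-1H-indazol-1-yl group leaves and a group with one five-membered aromatic ring with 2 hetero atoms and one six-membered aromatic ring with 1 hetero atom enters, on an aromatic carbon of a six-membered aromatic ring of carbon only, para to a large group. Among the measured compounds shown here, no measured pair in this set isolates such a change, so nothing measured fixes its size or direction. The expected step is a modest rise in the number, that is a 2.0-fold higher number from compound 1 to compound 3 (0.30 log units; within the scatter), towards weaker inhibition. Compound 3 is accordingly expected to give about 4000 nM, with a range from 1500 nM to 12000 nM.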

Compound 3, half-maximal inhibitory concentration: > 32000 nM
Compound 3 ended at the assay's limit; the forecaster's own chance of this, stated with the estimate: 15%; middle value at least 8.0-fold (0.90 log units) away from the limit.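

In this assay, replacing the 4-bromo-1H-indazol-1-yl group on this aromatic carbon, para to a large group, with the entering group, whose six-membered aromatic ring has 1 hetero atom, gives an at least 16-fold higher number from compound 1 to compound 3 (1.20 log units; beyond the scatter). Among the compounds shown here, this is the first change in the set confined to one place, and it shows that the read-out at this position is sensitive to the group it carries, a step that lies beyond the scatter. The result for compound 3 is a limit of the assay and not a number, so the step gives only a lower bound on the change, and the full size remains unknown: the limit of > 32000 nM in this assay, at which 1 of the 3 values shown sits.

The entering group differs from the one it replaces both in lacking the bromine and in holding a ring nitrogen, and this single step cannot separate those two differences. The compounds shown also leave open how the read-out would respond to a smaller alteration at this position, such as a methyl group or a methoxy group in place of the bromine of the 4-bromo-1H-indazol-1-yl group.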